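The source may hold more compounds than are shown below. What is called first, only, known or untested is meant among the compounds shown, and "the series" means these compounds.

In a functional assay on MCF7 cells (Homo sapiens) for cytotoxicity, read by MTT assay, with a stated time of 96 h (on this read-out higher numbers stand for weaker inhibition and lower numbers for stronger inhibition), compound 3 (`COc1cc(C(=O)c2cn(-c3ccc(F)cc3)cc2-c2ccccc2F)cc(OC)c1OC`) gives 39 nM, level with compound 1 (`COc1cc(C(=O)c2cn(-c3cccc(N)c3)cc2-c2ccccc2Cl)cc(OC)c1OC`) at 40 nM. Compound 2 (`COc1cc(C(=O)c2cn(-c3ccc(C)cc3)cc2-c2ccccc2Cl)cc(OC)c1OC`) gives 180 nM, and its gap to each of the other two lies beyond the scatter. Compound 4 (`COc1cc(C(=O)c2cn(-c3ccc(F)cc3)cc2-c2ccccc2Cl)cc(OC)c1OC`) differs from compound 3 by one change on an aromatic carbon, 2-fluorophenyl to 2-chlorophenyl (chloro in place of fluoro on an aromatic carbon). For the measured compounds named here, no measured step covers this exchange. Going by the values given here, the only step available (a 4.5-fold higher number from compound 1 to compound 2 (0.65 log units; beyond the scatter)) keeps the 2-chlorophenyl and changes the group on the aromatic nitrogen, so it bears only indirectly, showing how widely numbers spread among 2-chlorophenyl compounds. A small move toward a higher number is expected, with nothing beyond the scatter. The expected step in this assay is a 1.8-fold higher number from compound 3 to compound 4 (0.25 log units; within the scatter). The estimate for compound 4 is 70 nM, with an expected range from 25 nM to 200 nM.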

Compound 4, half-maximal inhibitory concentration: 83 nM
Estimate against measurement, compound 4: 1.2-fold (0.07 log units) below; low and high end bracket the measured number.
By their numbers in this assay, from the lowest: compounds 3 and 1 (each within the scatter of the next); then compound 4; then compound 2.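

In this assay, the exchange at the aromatic carbon ortho to a large group now has a direct reading, a 2.1-fold higher number from compound 3 to compound 4 (0.33 log units; beyond the scatter) for chloro in place of fluoro, a modest step that shows the halogen here counts. With 2-chlorophenyl held, the group on the aromatic nitrogen moves the number by a similar size: a 2.2-fold lower number from compound 2 to compound 4 (0.34 log units; beyond the scatter) for fluoro in place of methyl and a 2.1-fold higher number from compound 1 to compound 4 (0.32 log units; beyond the scatter) for 4-fluorophenyl in place of 3-aminophenyl. Nothing available explains any of these steps.

As far as these compounds go, whether bromo or methoxy at this place would continue the step from fluoro to chloro stays open. So does whether 2-fluorophenyl and 3-aminophenyl, taken together, would shift the number further.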